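Bromopiperidine swap on the compound 2 scaffold

The source may report more compounds than this note shows. Statements on the series, on what has been measured and on what is new or still open speak of the compounds shown alone.

- compound 1 `CC1=NN(C(=O)CN2CCC(O)CC2)C(c2ccccc2O)C1` at 5710 nM
- compound 2 `CCC1CCCCN1CC(=O)N1N=C(c2cc3ccccc3oc2=O)CC1c1ccccc1` at 6000 nM

Among the measured compounds shown here, both values come from a functional assay on SGC-7901 cells (Homo sapiens) for cytotoxicity, read by MTT assay, with a stated time of 48 h (on this read-out higher numbers stand for weaker inhibition and lower numbers for stronger inhibition), and lie within the scatter of each other, so compound 2 stands level with compound 1 on the numbers so far. Compound 3 `O=C(CN1CCC(Br)CC1)N1N=C(c2cc3ccccc3oc2=O)CC1c1ccccc1` differs from compound 2 in one place, with 4-bromopiperidin-1-yl in place of 2-ethylpiperidin-1-yl on a saturated chain carbon bound to a carbonyl carbon on a saturated chain carbon bound to a carbonyl carbon. For the measured compounds named here, no measured pair isolates this change. No step beyond the scatter is expected in this assay in either direction. The estimated 1.2-fold lower number from compound 2 to compound 3 (0.08 log units; within the scatter) is expected to stay small. Compound 3 is estimated at 5000 nM (expected range 1700 nM to 15000 nM).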

Compound 3, half-maximal inhibitory concentration: 10300 nM
Compound 3: middle estimate off by 2.1-fold (0.31 log units), on the low side; the measured number falls inside the stated range.
By their numbers in this assay, from the lowest: compounds 1, 2 and 3 (each within the scatter of the next).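

In this assay, 4-bromopiperidin-1-yl in place of 2-ethylpiperidin-1-yl on a saturated chain carbon bound to a carbonyl carbon gives a 1.7-fold higher number from compound 2 to compound 3 (0.23 log units; within the scatter) as the first step read at this position. Among the compounds shown here, the shared core therefore accepts either substituted piperidine here without a step beyond the scatter, which the earlier compounds could not show.

Still open, on these data alone, is how a morpholine, a piperazine or an open-chain amine would read at this place in this assay. Nothing at hand gives a cause for the small step.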